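This account rests on a few compounds, and the source may have more. Where it says the series, first, only, none or still open, it means among the compounds named here.

Three related compounds have been measured in a physicochemical assay for solubility, read by spectrophotometry, measured as kinetic solubility, at pH 8, tested at 500 uM; on this read-out lower numbers stand for lower solubility and higher numbers for higher solubility. Compound 1 `Cn1ccc2ccc(-c3cc(Nc4ccccc4S(=O)(=O)Nc4cncnc4)cc4nccnc34)cc21` gives 254 ug/mL, and compound 2 `CN1CCC(NS(=O)(=O)c2ccccc2Nc2cc(-c3ccc4ccn(C)c4c3)c3nccnc3c2)C1` gives 26 ug/mL. Compound 3 `Cn1cc(CNC(=O)c2ccncc2Nc2cc(-c3ccc4ccn(C)c4c3)c3nccnc3c2)cn1` gives 127 ug/mL. That number lies within the usual scatter of the result for compound 1, and it is higher than the result for compound 2 by more than the scatter.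

The unmeasured compound 4 `CC(=O)N1CCCC(NC(=O)c2ccncc2Nc2cc(-c3ccc4ccn(C)c4c3)c3nccnc3c2)C1` keeps the rest of compound 3 and changes one group: 1-acetylpiperidin-3-yl in place of (1-methyl-1H-pyrazol-4-yl)methyl on an amide-type nitrogen. In short, 1-acetylpiperidin-3-yl stands in place of (1-methyl-1H-pyrazol-4-yl)methyl on an amide-type nitrogen.

For the measured compounds named here, no measured pair makes this exact change. The nearest guide is a 9.8-fold lower number from compound 1 to compound 2 (0.99 log units; beyond the scatter), where 1-methylpyrrolidin-3-yl stands in place of pyrimidin-5-yl on a sulfonamide nitrogen. That step also puts a non-aromatic ring where an aromatic one stood, but it occurs on a different kind of nitrogen and with different groups, so it is only a weak guide. It suggests a slight lean downward in this assay, but a step of that size is not expected here. The expected change is a 1.2-fold lower number from compound 3 to compound 4 (0.06 log units; within the scatter), which is no shift beyond the scatter. Compound 4 is estimated at 110 ug/mL, with an expected range from 40 ug/mL to 260 ug/mL.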

Compound 4, solubility: 212 ug/mL
Compound 4: middle estimate off by 1.9-fold (0.28 log units), on the low side; low and high end bracket the measured number.
By their numbers in this assay, from the lowest: compound 2; then compounds 3, 4 and 1 (each within the scatter of the next).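

On this amide-type nitrogen, the change to 1-acetylpiperidin-3-yl gives a 1.7-fold higher number from compound 3 to compound 4 (0.22 log units; within the scatter) in this assay and so shows that a six-membered non-aromatic ring carrying an acetyl group can stand where (1-methyl-1H-pyrazol-4-yl)methyl stood, with no shift beyond the scatter. The earlier step that put a non-aromatic ring in place of an aromatic one, a 9.8-fold lower number from compound 1 to compound 2 (0.99 log units; beyond the scatter) on a sulfonamide nitrogen, is not repeated here, so these two steps give no single outcome for such a swap, and they also differ in the nitrogen and in the groups involved. Nothing measured here explains the difference between the two steps.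

The compounds shown leave open how this amide-type nitrogen would respond to a free amine, such as piperidin-3-yl without its acetyl, or to a ring carrying a carboxylic acid. They also leave open whether 1-methylpyrrolidin-3-yl, the group of compound 2, would give a large step on this nitrogen or stay within the scatter as 1-acetylpiperidin-3-yl does.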